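Acetyl gives way to methyl

This account rests on a few compounds, and the source may have more. Where it says the series, first, only, none or still open, it means among the compounds named here.

Measured in a functional assay (aorta) with Rattus norvegicus as the target; a higher number here means a weaker inhibitor, a lower number a stronger inhibitor
compound 1 (`CC1(C)Oc2ccc(C#N)cc2[C@@H](/N=C(\NC#N)Nc2ccccc2)[C@@H]1O`) gives 1400 nM; 1300 nM (2 entries)
compound 2 (`CC1(C)Oc2ccc(C#N)cc2[C@@H](/N=C(\NC#N)Nc2ccc(N)cc2)[C@@H]1O`) gives 3500 nM
compound 3 (`CC(=O)c1ccc(N/C(=N/[C@@H]2c3cc(C#N)ccc3OC(C)(C)[C@H]2O)NC#N)cc1`) gives 21000 nM

Compound 3 has the highest single number of the group, and the nearest number belongs to compound 2. Compound 4 (`Cc1ccc(N/C(=N/[C@@H]2c3cc(C#N)ccc3OC(C)(C)[C@H]2O)NC#N)cc1`) is still unmeasured and carries methyl in place of acetyl on an aromatic carbon para to a large group. Among the measured compounds shown here, one measured step bears on this change: acetyl in place of amino on an aromatic carbon gave a 6.0-fold higher number from compound 2 to compound 3 (0.78 log units; beyond the scatter) as the only such comparison. Compound 1, with neither group, gives 1400 nM; 1300 nM (2 entries) in this assay and so offers a second reference. Losing the acetyl is therefore expected to bring a lower number of similar size in this assay with an 8.4-fold lower number from compound 3 to compound 4 (0.92 log units; beyond the scatter) as the estimated step. The estimate for compound 4 is 2500 nM with 900 nM to 7000 nM as its expected range.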

Compound 4, half-maximal inhibitory concentration: 2700 nM
Beside the measured number, compound 4's estimate is 1.1-fold (0.03 log units) below it; the range from low to high includes it.
By their numbers in this assay, from the lowest: compounds 4 and 2 (each within the scatter of the next); then compound 3.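

In this assay, the high number seen with acetyl does not carry over to methyl at this position: the change brings a 7.8-fold lower number from compound 3 to compound 4 (0.89 log units; beyond the scatter). Methyl and amino cannot be told apart here, with a 1.3-fold lower number from compound 2 to compound 4 (0.11 log units; within the scatter), so among these three compounds only the acetyl compound 3 stands apart. The reference with neither group is consistent across its repeats: the several entries of compound 1 in this assay, 1400 nM; 1300 nM (2 entries)

From the compounds shown here alone, it remains open whether a carboxylic acid, a chlorine atom or a longer chain here would group with compound 3 or with compound 2 and compound 4. Also open, going by these compounds, is whether any group at this position could bring the number below that of compound 1.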